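This account rests on a few compounds, and the source may have more. Where it says the series, first, only, none or still open, it means among the compounds named here.

Working notes on the cytotoxicity series.

Of the compounds shown here, three sharing one core have been measured. Compound 1 `CN1CCN(C[C@H]2CN(c3ccc(-n4cc(-c5ccccn5)cn4)c(F)c3)C(=O)O2)CC1` gives 70 ug/mL in an ADME assay on L02 cells (Homo sapiens) for cytotoxicity, read by MTT assay, with a stated time of 48 h; on this read-out lower numbers stand for stronger inhibition and higher numbers for weaker inhibition. Compound 2 `CCN1CCN(C[C@H]2CN(c3ccc(-n4cc(-c5ccccn5)cn4)c(F)c3)C(=O)O2)CC1` gives 99 ug/mL in this assay, and compound 3 `CCC(=O)NC[C@H]1CN(c2ccc(-n3cc(-c4ccccn4)cn3)c(F)c2)C(=O)O1` gives 204 ug/mL in this assay. Compound 3 stands at the highest number of the three, meaning the weakest inhibition measured so far; the step of a 2.9-fold higher number from compound 1 to compound 3 (0.46 log units; beyond the scatter) and the step of a 2.1-fold higher number from compound 2 to compound 3 (0.31 log units; beyond the scatter) both run upward and both lie beyond the scatter, while the step of a 1.4-fold higher number from compound 1 to compound 2 (0.15 log units; within the scatter) stays within it.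

Compound 4 `O=C1O[C@@H](CNC(=O)C(F)(F)F)CN1c1ccc(-n2cc(-c3ccccn3)cn2)c(F)c1` differs from compound 3 only at the acyl end: trifluoromethyl in place of ethyl on a carbonyl carbon. Going by the values given here, no measured step in this set touches the acyl group; the two steps that reach compound 3 both exchange a piperazinyl group for the propanoylamino group, and the remaining step changes only a substituent on the ring amine. The effect of exchanging ethyl for trifluoromethyl on the carbonyl carbon is therefore unknown here, and no step beyond the scatter is expected in this assay.

The number for compound 4 is accordingly estimated near that of compound 3, with the expected step of a 1.0-fold lower number from compound 3 to compound 4 (0.01 log units; within the scatter) lying within the scatter. Compound 4 is estimated at 200 ug/mL, with a range from 90 ug/mL to 450 ug/mL.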

Compound 4, half-maximal inhibitory concentration: > 400 ug/mL
Compound 4 ended at the assay's limit (the forecaster's own chance of this, stated with the estimate: 20%); middle value at least 2.0-fold (0.30 log units) away from the limit.
By their numbers in this assay, from the lowest: compounds 1 and 2 (each within the scatter of the next); then compound 3. At a limit, above all of these: compound 4.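

The acyl end now has its first reading: trifluoromethyl in place of ethyl on a carbonyl carbon gives an at least 1.9-fold higher number from compound 3 to compound 4 (0.29 log units; that floor lies within the scatter), a floor that alone does not set compound 4 beyond the scatter from compound 3. The piperazinyl exchanges, however, grow once the acyl end changes: ((trifluoromethyl)carbonyl)amino in place of the piperazinyl groups gives an at least 4.0-fold higher number from compound 2 to compound 4 (0.60 log units; beyond the scatter) and an at least 5.7-fold higher number from compound 1 to compound 4 (0.75 log units; beyond the scatter), both beyond the scatter. Compound 4 sits at a limit of this assay, not at a number: the limit of > 400 ug/mL in this assay, at which 1 of the 4 values shown sits.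

As far as these compounds go, how far compound 4 lies past that limit stays open, and with it the true size of all three steps. Also open, from the compounds shown here alone, is how a methyl or a longer alkyl chain on the same carbonyl carbon would read in this assay.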